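Chloro to cyano: an expectation from three compounds

The compounds below may be only part of what the source reports. "The series", "measured", "known", "first", "only" and "open" are said of these compounds alone.

Compound 1 `O=C1/C(=C/c2cccnc2)CN(S(=O)(=O)c2ccc([N+](=O)[O-])cc2)C/C1=C\c1ccccc1F` at 12800 nM
Compound 2 `O=C1/C(=C/c2cccnc2)CN(S(=O)(=O)c2ccc(C(F)(F)F)cc2)C/C1=C\c1ccccc1F` at 2400 nM
Compound 3 `O=C1/C(=C/c2cccnc2)CN(S(=O)(=O)c2ccc(Cl)cc2)C/C1=C\c1ccccc1F` at 12400 nM

In a functional assay on HepG2 cells (Homo sapiens) for cytotoxicity, read by MTT assay, with a stated time of 24 h (a lower number here means a stronger inhibitor, a higher number a weaker inhibitor), the numbers show a 1.0-fold lower number from compound 1 to compound 3 (0.01 log units; within the scatter) and also a 5.2-fold higher number from compound 2 to compound 3 (0.71 log units; beyond the scatter) so compound 3 sits level with compound 1 and higher than compound 2. Compound 4 `N#Cc1ccc(S(=O)(=O)N2C/C(=C\c3cccnc3)C(=O)/C(=C/c3ccccc3F)C2)cc1` has cyano in place of chloro on an aromatic carbon, para to a large group (cyano in place of chloro on an aromatic carbon). For the measured compounds named here, no measured step involves cyano. Going by the values given here, two steps bear on this place, chloro in place of nitro (a 1.0-fold lower number from compound 1 to compound 3 (0.01 log units; within the scatter)) and trifluoromethyl in place of nitro (a 5.3-fold lower number from compound 1 to compound 2 (0.73 log units; beyond the scatter)). They run from none to modest, so no step beyond the scatter is expected in this assay and the estimated change is (a 1.2-fold lower number from compound 3 to compound 4 (0.09 log units; within the scatter)). For compound 4 the estimated value is 10000 nM with an expected range from 4000 nM to 20000 nM in this measurement.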

Compound 4, half-maximal inhibitory concentration: 6600 nM
Compound 4: the middle estimate sits 1.5-fold (0.18 log units) above what was measured, and the stated range covers the measured number.
By their numbers in this assay, from the lowest: compound 2; then compounds 4, 3 and 1 (each within the scatter of the next).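

In this assay compound 4 reads with the chloro and nitro compounds, since a 1.9-fold lower number from compound 3 to compound 4 (0.27 log units; within the scatter) and a 1.9-fold lower number from compound 1 to compound 4 (0.29 log units; within the scatter) both stay within the usual scatter. Trifluoromethyl alone stands apart, as a 2.8-fold higher number from compound 2 to compound 4 (0.44 log units; beyond the scatter) shows, so three of the four groups at this position now read alike and compound 2 is the only exception. Nothing measured here explains why trifluoromethyl differs. The compounds shown leave open whether an amine, a carboxylic acid or a methyl at this position would read with compound 2 or with the other three.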